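The source may report more compounds than this note shows. Statements on the series, on what has been measured and on what is new or still open speak of the compounds shown alone.

Two pairs of compounds share one small change. Compound 1 `COc1ccc(-c2ssc(=O)c2-c2cc(OC)c(OC)c(OC)c2)cc1` and compound 2 `COc1ccc(-c2ssc(=O)c2-c2cc(OC)c(OC)c(OC)c2)cc1O` differ in a single place: hydroxy in place of hydrogen on an aromatic carbon. In a functional assay on HT-1080 cells (Homo sapiens) for antiproliferative activity, read by MTT assay, with a stated time of 72 h (a lower number here means a stronger inhibitor, a higher number a weaker inhibitor), compound 1 gives 464 nM, and compound 2 gives 1910 nM, so this change produced a 4.1-fold higher number from compound 1 to compound 2 (0.61 log units; beyond the scatter). Compound 3 `COc1ccc(-c2ss/c(=N/O)c2-c2cc(OC)c(OC)c(OC)c2)cc1` carries a different core; the difference between the core of compound 1 and the core of compound 3 is not broken down here. In this assay compound 3 gives 6660 nM, the highest number among the three measured compounds. Compound 4 `COc1ccc(-c2ss/c(=N/O)c2-c2cc(OC)c(OC)c(OC)c2)cc1O` has not yet been measured. It stands to compound 3 exactly as compound 2 stands to compound 1, the same change: hydroxy in place of hydrogen on an aromatic carbon. If the change acts on the core of compound 3 as it acted on the core of compound 1, the step from compound 3 to compound 4 is expected to be a 3.3-fold higher number from compound 3 to compound 4 (0.52 log units; beyond the scatter), an expectation that rests on a 4.1-fold higher number from compound 1 to compound 2 (0.61 log units; beyond the scatter). Compound 4 is therefore estimated to give 22000 nM in this assay. The change has been seen only once, on another core, which leaves the expected range for compound 4 wide, from 8000 nM to 60000 nM.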

Compound 4, half-maximal inhibitory concentration: 730 nM
The estimate for compound 4 lay 30-fold (1.48 log units) above the measured number; measured number outside the range, below it.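

On the core of compound 3, the hydroxy change gives a 9.1-fold lower number from compound 3 to compound 4 (0.96 log units; beyond the scatter) in this assay, so here it makes the compound a stronger inhibitor, whereas on the core of compound 1 it made the compound a weaker one. The change therefore does not carry over from one core to the other in this series, not even in its direction: the same change on two cores in this assay, a 4.1-fold higher number (0.61 log units; beyond the scatter) from compound 1 to compound 2 and a 9.1-fold lower number (0.96 log units; beyond the scatter) from compound 3 to compound 4, 38-fold (1.57 log units) apart, beyond the scatter of two such steps

This shows that the result of adding this hydroxy group depends on the core that carries it, so a step read on one core is a poor guide to the other. Among the compounds shown here, with only one pair on each core, it does not show why the two cores part, or how the change would behave on a further core.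

The compounds shown leave open whether an amine or a fluorine atom on the same aromatic carbon would also split the two cores in this way. They also leave open whether a longer chain in place of the methoxy group would do so.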